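The source may report more compounds than this note shows. Statements on the series, on what has been measured and on what is new or still open speak of the compounds shown alone.

Measured in a functional assay (aorta) with Oryctolagus cuniculus as the target; a lower number here means tighter binding, a higher number weaker binding:
- compound 1 `COc1cc(C(C)=O)ccc1OCCCN1CCC(C(c2ccc(F)cc2)c2ccc(F)cc2)CC1` gives 1.59 nM
- compound 2 `COc1cc(C(C)=O)ccc1OCCCN1CCC(C(c2cccc(F)c2)c2cccc(F)c2)CC1` gives 3.16 nM

These two numbers lie within the usual scatter of each other, so compound 1 does not stand apart from compound 2. Compound 3 `COc1cc(C(C)=O)ccc1OCCCN1CCC(C(c2ccc(F)cc2)C2CCCCC2)CC1` has not been measured. It carries cyclohexyl in place of 4-fluorophenyl on a saturated chain carbon bound to an aromatic carbon and a saturated ring carbon. Among the compounds with values here, no measured pair shows this kind of swap, so the expectation is tentative. An estimated step of a 3.8-fold higher number from compound 1 to compound 3 (0.58 log units; beyond the scatter) is expected, a moderate move towards weaker binding in this assay that may not clear the scatter by much. Compound 3 is expected to give about 6 nM with an estimated range from 1.5 nM to 25 nM in that assay.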

Compound 3, dissociation constant: 5.01 nM
Estimate against measurement, compound 3: 1.2-fold (0.08 log units) above; measured number inside the range.
By their numbers in this assay, from the lowest: compounds 1, 2 and 3 (each within the scatter of the next, the first and the last beyond it).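

In this assay, cyclohexyl in place of 4-fluorophenyl on this saturated chain carbon gives a 3.2-fold higher number from compound 1 to compound 3 (0.50 log units; beyond the scatter), a modest step towards weaker binding that lies beyond the scatter. An aromatic ring at this place is therefore not essential for binding, as compound 3 still gives 5.01 nM. Nothing available explains the size of this step.

On these data alone, the swap removes the fluorine and the aromatic ring together, so their separate contributions remain unknown. As far as these compounds go, a plain phenyl at this place would separate the two, and how a small amine would read here remains open.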